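Moving a methyl on the sulfonyl aryl ring

The source may report more compounds than this note shows. Statements on the series, on what has been measured and on what is new or still open speak of the compounds shown alone.

Measured compounds:
compound 1 `Cc1cccc(S(=O)(=O)NCc2ccc(CNC(=O)c3ccc(CNc4ncccn4)cc3)cc2)c1` with 100 nM
compound 2 `O=C(NCc1ccc(CNS(=O)(=O)c2ccc([N+](=O)[O-])cc2)cc1)c1ccc(CNc2ncccn2)cc1` with 1000 nM
compound 3 `O=C(NCc1ccc(CNS(=O)(=O)c2cccc(F)c2)cc1)c1ccc(CNc2ncccn2)cc1` with 1000 nM

These three compounds were tested in an assay on MDA-MB-231 cells for binding affinity to C-X-C chemokine receptor type 4 (Homo sapiens), read by microscopy, with stated times of 10 min and 30 min; on this read-out higher numbers stand for an effect only at larger amounts of compound and lower numbers for an effect already at smaller amounts. Compound 1 holds the lowest number of the three, and both other compounds stand apart from it beyond the scatter: a 10-fold higher number from compound 1 to compound 2 (1.00 log units; beyond the scatter) and a 10-fold higher number from compound 1 to compound 3 (1.00 log units; beyond the scatter). Compound 2 and compound 3 are not apart from each other, since no change at the digits printed from compound 2 to compound 3 (within the scatter).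

Compound 4 `Cc1ccc(S(=O)(=O)NCc2ccc(CNC(=O)c3ccc(CNc4ncccn4)cc3)cc2)cc1` has not yet been measured. It differs from compound 1 in one place: 4-methylphenyl in place of 3-methylphenyl on a sulfonyl sulfur.

For the measured compounds named here, no measured step moves a methyl from one ring position to another, so none bears directly on this change. The two steps that do start from compound 1 each swap the group on the sulfonyl sulfur for something else and each cost the same amount, a 10-fold higher number from compound 1 to compound 2 (1.00 log units; beyond the scatter) and a 10-fold higher number from compound 1 to compound 3 (1.00 log units; beyond the scatter). Because of a 10-fold higher number from compound 1 to compound 2 (1.00 log units; beyond the scatter) and a 10-fold higher number from compound 1 to compound 3 (1.00 log units; beyond the scatter), a change at this position is expected to carry some risk of a higher number, but a methyl kept on the ring is a smaller change than either, so only a modest step is expected: a 2.5-fold higher number from compound 1 to compound 4 (0.40 log units; beyond the scatter). For compound 4 the estimate in this assay is 250 nM, with a range from 80 nM to 1000 nM.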

Compound 4, effective concentration (reported as EC, without a stated level of effect): 100 nM
The estimate for compound 4 lay 2.5-fold (0.40 log units) above the measured number, within the range that was stated.
By their numbers in this assay, from the lowest: compounds 1 and 4 (each within the scatter of the next); then compounds 2 and 3 (each within the scatter of the next).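

In this assay, for the compounds shown here, moving the methyl from 3-methylphenyl to 4-methylphenyl on the sulfonyl sulfur gives no change at the digits printed from compound 1 to compound 4 (within the scatter), so the ring place of this methyl does not register here, something the earlier compounds could not show. Compound 4 also stands apart from the other two, with a 10-fold lower number from compound 3 to compound 4 (1.00 log units; beyond the scatter) and a 10-fold lower number from compound 2 to compound 4 (1.00 log units; beyond the scatter), so among these four compounds, both methylphenyl groups go with the lower numbers, and the 3-fluorophenyl and 4-nitrophenyl groups go with the higher ones. No measurement at hand accounts for this pattern.

The compounds shown leave open whether a longer chain such as ethyl or propyl in place of the methyl would hold the number. They also leave open how an amine or a carboxylic acid on this ring would fare.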